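The source may report more compounds than this note shows. Statements on the series, on what has been measured and on what is new or still open speak of the compounds shown alone.

In an ADME assay on HEK293 cells (Homo sapiens) for cytotoxicity, read by reporter gene assay and resazurin assay, with a stated time of 48 h (a lower number here means that less compound is tolerated, a higher number that more compound is tolerated), compound 3 `COc1ccccc1C(=O)Nc1ccc(Sc2nc3ccccc3s2)c(Cl)c1` gives > 100000 nM, which is a limit of the assay and not a number. Compound 1 `O=C(Nc1ccc(Sc2nc3ccccc3s2)c(Cl)c1)c1cc(Br)cc(Br)c1` gives > 100000 nM, which is also a limit. Compound 2 `O=C(Nc1ccc(Sc2nc3ccccc3s2)c(Cl)c1)c1cccc(Br)c1O` gives a measured 64000 nM. The series thus shows (the limit of > 100000 nM in this assay, at which 2 of the 3 values shown sit), and compound 3 has no exact place on the scale.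

The next structure, compound 4 `COc1c(Br)cccc1C(=O)Nc1ccc(Sc2nc3ccccc3s2)c(Cl)c1`, has bromo in place of hydrogen on an aromatic carbon, ortho to a methoxy group and meta to a large group: bromo in place of hydrogen on an aromatic carbon. Among the measured compounds shown here, two measured steps bear on this change, and both involve compound 2, which also carries a bromo group. They are an at least 1.5-fold higher number from compound 2 to compound 3 (0.19 log units; that floor lies within the scatter) and an at least 1.5-fold lower number from compound 1 to compound 2 (0.19 log units; that floor lies within the scatter), and the floor of each lies within the scatter. The third comparison, a step that the two limits leave unreadable from compound 1 to compound 3, cannot be read. None of these steps therefore points to a large effect in this assay, and only a small shift towards a lower number is expected. The estimated step is an at least 1.2-fold lower number from compound 3 to compound 4 (0.09 log units; that floor lies within the scatter), which may not exceed the scatter. Compound 4 is estimated at 80000 nM, with an expected range from 35000 nM to 150000 nM.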

Compound 4, half-maximal cytotoxic concentration: > 100000 nM
Compound 4 was reported as a limit; the forecaster's own chance of this, stated with the estimate: 45%; middle value at least 1.2-fold (0.09 log units) away from the limit.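

In this assay compound 4 gives > 100000 nM, a limit of the assay, so bromo at this place, ortho to a methoxy group and meta to a large group, brings no readable move to a lower number. The steps to compound 4 from compound 3 and from compound 1 cannot be read, because each pair has both values at a limit: the limit of > 100000 nM in this assay, at which 3 of the 4 values shown sit.

With the bromo group kept, methyl in place of hydrogen on the oxygen gives an at least 1.5-fold higher number from compound 2 to compound 4 (0.19 log units; that floor lies within the scatter).

The compounds shown leave open how far beyond the limit compound 1, compound 3 and compound 4 lie. They also leave open whether an amine or a carboxylic acid in place of the bromo group of compound 4 would give a measured value.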